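The source may hold more compounds than are shown below. What is called first, only, known or untested is meant among the compounds shown, and "the series" means these compounds.

Of the compounds shown here, three sharing one core have been measured in a functional assay on A549 cells (Homo sapiens) for antiproliferative activity, read by XTT assay, with a stated time of 72 h; a higher number here means a weaker inhibitor, a lower number a stronger inhibitor. Compound 1 (`C=C(C)CCC[C@]1(C)C2=CCC[C@](C)(C[C@@H](OC(C)=O)C3=CC(=O)OC3O)[C@H]2CC[C@H]1C`) gives 3200 nM, compound 2 (`C=C(C)CCC[C@]1(C)C2=CCC[C@](C)(C[C@@H](O)C3=CC(=O)OC3O)[C@H]2CC[C@H]1C`) gives 3800 nM and compound 3 (`C=C(C)CC[C@]1(C)C2=CCC[C@](C)(C[C@@H](O)C3=CC(=O)OC3O)[C@H]2CC[C@H]1C`) gives 4400 nM. Compound 2 therefore sits in a tight group, with nothing that separates it from the other two.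

Compound 4 (`C=C(C)CCC[C@]1(C)C2=CCC[C@](C)(C[C@H](O)c3ccoc3)[C@H]2CC[C@H]1C`) makes a bigger change to compound 2: a group of 7 heavy atoms (5 carbon, 2 oxygen; one five-membered aromatic ring with 1 hetero atom) in place of a group of 9 heavy atoms (5 carbon, 4 oxygen; one five-membered non-aromatic ring with 1 hetero atom), on a saturated chain carbon bound to a saturated ring carbon. In words, (furan-3-yl)(hydroxy)methyl enters on a saturated chain carbon bound to a saturated ring carbon, and the five-membered non-aromatic ring leaves.

Two measured steps offer guidance, though only partly. Swapping acetyl for hydrogen on an oxygen gives a 1.2-fold higher number from compound 1 to compound 2 (0.07 log units; within the scatter), and swapping the chain end gives a 1.2-fold higher number from compound 2 to compound 3 (0.06 log units; within the scatter). Both are small, but both keep the five-membered non-aromatic ring, so neither shows what happens when it is replaced. Within the data shown here, that ring is shared by all three measured compounds, and no measured compound lacks it. The expectation is therefore a judgement: a move to a higher number, meaning a weaker inhibitor, and beyond the scatter. The estimated step is a 3.9-fold higher number from compound 2 to compound 4 (0.60 log units; beyond the scatter). For compound 4 the expected value is 15000 nM, with an estimated range from 5000 nM to 45000 nM.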

Compound 4, half-maximal inhibitory concentration: 66000 nM
For compound 4 the middle estimate is 4.4-fold (0.64 log units) below the measured one, and the stated range ends below it.
By their numbers in this assay, from the lowest: compounds 1, 2 and 3 (each within the scatter of the next); then compound 4.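

Each step among compounds 1, 2 and 3 stayed within the scatter, so neither the acetyl on the oxygen nor the chain end showed any clear effect on the number. Among these compounds, replacing the five-membered non-aromatic ring with the aromatic furan-3-yl ring, on a saturated chain carbon bound to a saturated ring carbon, gives in this assay a large change, a 17-fold higher number from compound 2 to compound 4 (1.24 log units; beyond the scatter), and this is the first change to go beyond the scatter. This position therefore responds strongly to this replacement, but nothing in the available data explains the loss of activity.

The swap alters the ring, the double bonds outside aromatic rings and the counts of hydrogen-bond donors and acceptors all at once, so the compounds shown cannot say which of these differences matters. Going by these compounds, it also remains open how a phenyl group or a carboxylic acid in this place would compare, and whether the acetyl on the oxygen or the shorter chain end would behave the same way alongside the furan-3-yl ring.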